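Adding a Nitro Group to Compound 1

The source may hold more compounds than are shown below. What is called first, only, known or untested is meant among the compounds shown, and "the series" means these compounds.

Compound 1 `CC(O)Cn1c([N+](=O)[O-])cnc1/C=C/c1ccccc1` has the highest number of the three measured compounds in an ADME assay on cells (Macrophage, Homo sapiens) for cytotoxicity, read by MTT assay, with a stated time of 24 h (a lower number here means that less compound is tolerated, a higher number that more compound is tolerated), where compound 1 gives 1500 nM. Compound 2 `COc1ccccc1/C=C/c1ncc([N+](=O)[O-])n1CC(C)O` gives 480 nM, and compound 3 `CC(O)Cn1c([N+](=O)[O-])cnc1/C=C/c1ccc(N(C)C)cc1` gives 680 nM. Each of those two carries a single added group on the six-membered aromatic ring of carbon only, and each addition lowered the number: a 3.1-fold lower number from compound 1 to compound 2 (0.49 log units; beyond the scatter), and a 2.2-fold lower number from compound 1 to compound 3 (0.34 log units; beyond the scatter). Compound 4 `CC(O)Cn1c([N+](=O)[O-])cnc1/C=C/c1cccc([N+](=O)[O-])c1` differs from compound 1 by nitro in place of hydrogen on an aromatic carbon. Both measured steps point the same way, so a modest lowering is expected, a 2.0-fold lower number from compound 1 to compound 4 (0.30 log units; within the scatter). The estimate for compound 4 in this assay is 750 nM, with a range from 350 nM to 1600 nM.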

Compound 4, half-maximal cytotoxic concentration: 430 nM
For compound 4 the middle estimate is 1.7-fold (0.24 log units) above the measured one; measured number inside the range.
By their numbers in this assay, from the lowest: compounds 4, 2 and 3 (each within the scatter of the next); then compound 1.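

In this assay, nitro in place of hydrogen on an aromatic carbon, meta to a large group, gives a 3.5-fold lower number from compound 1 to compound 4 (0.54 log units; beyond the scatter). This makes a third group on the six-membered aromatic ring that lowers the number from that of compound 1, and no compound shown goes against this. No measurement shown gives a reason for the lowering.

Going by these compounds, whether a carboxylic acid or a fluorine atom at this same place would also lower the number remains open. So does whether nitro on another carbon of that ring would give a step of the same size.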